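The source may report more compounds than this note shows. Statements on the series, on what has been measured and on what is new or still open speak of the compounds shown alone.

Compound 2 `C#CCN(CCCOc1ccc2ccc(=O)oc2c1)Cc1cccc(OC)c1` and compound 1 `C#CCN(CCCOc1ccc2ccc(=O)oc2c1)Cc1ccccc1` share the same core and differ only by a single group on a six-membered aromatic ring. In an ADME assay on isolated protein for inhibition of Amine oxidase [flavin-containing] A (Homo sapiens), read by fluorescence and Amplex Red, with stated times of 15 min and 20 min (a higher number here means a weaker inhibitor, a lower number a stronger inhibitor), compound 1 gives 38600 nM, and in the same assay compound 2 gives 22700 nM. Within the data shown here, of the two numbers, that of compound 2 is the smaller, but the only measured step, a 1.7-fold lower number from compound 1 to compound 2 (0.23 log units; within the scatter), stays within the scatter, so neither compound can be called the stronger inhibitor on this evidence. Compound 3 `C#CCN(CCCOc1ccc2ccc(=O)oc2c1)Cc1cccc(F)c1` has not yet been measured. It differs from compound 2 by fluoro in place of methoxy on an aromatic carbon. Among the measured compounds shown here, no measured pair shows exactly this exchange; the closest guide is the step from compound 1 to compound 2, where methoxy in place of hydrogen on an aromatic carbon produced a 1.7-fold lower number from compound 1 to compound 2 (0.23 log units; within the scatter). Since that related change left the number essentially where it was, fluoro in place of methoxy is expected to do much the same, with no step beyond the scatter in this assay. Compound 3 is therefore estimated at 30000 nM, with a likely range from 12000 nM to 75000 nM. The expected step is a 1.3-fold higher number from compound 2 to compound 3 (0.12 log units; within the scatter).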

Compound 3, half-maximal inhibitory concentration: 29300 nM
Compound 3: middle estimate off by 1.0-fold (0.01 log units), on the high side; low and high end bracket the measured number.
By their numbers in this assay, from the lowest: compounds 2, 3 and 1 (each within the scatter of the next).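

In this assay, fluoro in place of methoxy gives a 1.3-fold higher number from compound 2 to compound 3 (0.11 log units; within the scatter), and fluoro in place of hydrogen gives a 1.3-fold lower number from compound 1 to compound 3 (0.12 log units; within the scatter), so all three pairs among these compounds are now measured and none of them can be told apart. At this place, an aromatic carbon meta to a large group, hydrogen, methoxy and fluoro therefore give numbers within the scatter of one another, even though going from methoxy to fluoro takes the group from two heavy atoms to one and from one hydrogen-bond acceptor to none. No measurement is available that could explain why these numbers lie so close together.

The compounds shown leave open whether any group at this place can move the number beyond the scatter, for instance an amine, a carboxylic acid or a longer chain such as butoxy. They also leave open whether fluoro or methoxy would behave the same way at another place on this ring, since every substituent here sits at this one position.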